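The source may report more compounds than this note shows. Statements on the series, on what has been measured and on what is new or still open speak of the compounds shown alone.

Compound 1, `COc1cccc(NC(=O)Nc2cccc(-c3nc(-c4ccc(NC(=O)c5cccnc5)cc4Cl)no3)c2)c1`: in a functional assay on MDA-MB-231 cells (Homo sapiens) for antiproliferative activity, read by MTT assay, with a stated time of 72 h (on this read-out higher numbers stand for weaker inhibition and lower numbers for stronger inhibition), compound 1 gives 6700 nM.
Compound 2, `CS(=O)(=O)Nc1cccc(NC(=O)Nc2cccc(-c3nc(-c4ccc(NC(=O)c5cccnc5)cc4Cl)no3)c2)c1`: compound 2 gives > 10000 nM, which is a limit of this assay and not a number.
Compound 3, `CS(=O)(=O)Nc1ccc(NC(=O)Nc2cccc(-c3nc(-c4ccc(NC(=O)c5cccnc5)cc4Cl)no3)c2)cc1`: compound 3 gives 600 nM.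

Among the numbers shown, compound 3 stands lowest: the step of an 11-fold lower number from compound 1 to compound 3 (1.05 log units; beyond the scatter) separates it from its nearest neighbour, and the step of an at least 16-fold lower number from compound 2 to compound 3 (1.22 log units; beyond the scatter) separates it from the limit. The smaller step of an at least 1.4-fold higher number from compound 1 to compound 2 (0.17 log units; that floor lies within the scatter) changes only the group on the outer ring.

Compound 4, `CS(=O)(=O)Nc1ccc(NC(=O)Nc2cccc(-c3nc(-c4ccc(NC(=O)c5cccnc5)cc4Cl)no3)c2)cc1Cl`, differs from compound 3 by chloro in place of hydrogen on an aromatic carbon, ortho to the methanesulfonamido group and meta to a large group; seen one bond further out, 4-(methanesulfonamido)phenyl becomes 3-chloro-4-(methanesulfonamido)phenyl. Among the compounds with values here, none of the measured steps adds a chloro; all three swap or move the group on that ring, so they bear on the change only loosely. In this assay the step of a 1.2-fold higher number from compound 3 to compound 4 (0.07 log units; within the scatter) is therefore expected to stay within the scatter, in no fixed direction. Compound 4 is estimated at 700 nM, between 250 nM and 2000 nM.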

Compound 4, half-maximal inhibitory concentration: 600 nM
For compound 4 the middle estimate is 1.2-fold (0.07 log units) above the measured one, within the range that was stated.
By their numbers in this assay, from the lowest: compounds 3 and 4 (each within the scatter of the next); then compound 1. At a limit, above all of these: compound 2.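

In this assay, a chloro ortho to the methanesulfonamido group leaves the result unmoved, which the earlier swaps on this ring could not show: no change at the digits printed from compound 3 to compound 4 (within the scatter). The chloro also keeps the large difference from the other two compounds, seen in an 11-fold lower number from compound 1 to compound 4 (1.05 log units; beyond the scatter) and in an at least 16-fold lower number from compound 2 to compound 4 (1.22 log units; beyond the scatter). Compound 2 stands at a limit of the assay, not at a number: the limit of > 10000 nM in this assay, at which 1 of the 4 values shown sits.

Chloro is the only group shown at this position, so it remains open whether a fluoro, a methyl, a methoxy or an amine placed there would also leave the value in this assay unchanged. Also open, on these data alone, is whether the chloro would matter in any cell line other than this one.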